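Swapping the chalcone arm on a pyrazolopyrimidine scaffold

This account rests on a few compounds, and the source may have more. Where it says the series, first, only, none or still open, it means among the compounds named here.

Of the compounds shown here, three sharing one core have been tested in a functional assay on MDA-MB-231 cells (Homo sapiens) for antiproliferative activity, read by MTT assay, with a stated time of 24 h; on this read-out higher numbers stand for weaker inhibition and lower numbers for stronger inhibition. Compound 1 `COc1ccc(-c2cc(C(=O)/C=C/c3ccccc3)nc3cc(-c4ccccc4)nn23)cc1OC` gives 23300 nM, the highest of the three numbers, though every gap to the others stays within the scatter. Compound 2 `COc1ccc(C(=O)/C=C/c2cc(-c3cc(OC)c(OC)c(OC)c3)n3nc(-c4ccccc4)cc3n2)cc1` gives 13200 nM and compound 3 `COc1cc(-c2cc(C(=O)/C=C/c3ccccc3)nc3cc(-c4ccccc4)nn23)cc(OC)c1OC` gives 19200 nM. The change from compound 1 to compound 4 `COc1ccc(-c2cc(/C=C/C(=O)c3ccc(C)c(C)c3)nc3cc(-c4ccccc4)nn23)cc1OC` is 2-((3,4-dimethylphenyl)carbonyl)ethenyl in place of (2-phenylethenyl)carbonyl on an aromatic carbon. The closest comparison is a 1.5-fold higher number from compound 2 to compound 3 (0.16 log units; within the scatter), which exchanges the same two kinds of arm together with a change in the distant phenyl substituents; the step of a 1.2-fold lower number from compound 1 to compound 3 (0.08 log units; within the scatter) shows that methoxy groups on the aryl ring also move the numbers little. Among the measured compounds shown here, no step here exceeds the scatter, so for compound 4 only a change within the scatter, a 1.3-fold lower number from compound 1 to compound 4 (0.11 log units; within the scatter), is expected, with an estimate of 18000 nM in this assay, ranging from 6000 nM to 50000 nM.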

Compound 4, half-maximal inhibitory concentration: 11500 nM
Beside the measured number, compound 4's estimate is 1.6-fold (0.19 log units) above it; low and high end bracket the measured number.
By their numbers in this assay, from the lowest: compounds 4, 2, 3 and 1 (each within the scatter of the next, the first and the last beyond it).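

In this assay, among the compounds shown here, the swap of (2-phenylethenyl)carbonyl for 2-((3,4-dimethylphenyl)carbonyl)ethenyl gives a 2.0-fold lower number from compound 1 to compound 4 (0.31 log units; beyond the scatter) and is the first step here to pass the scatter, though only modestly. This position, on the aromatic carbon next to the ring nitrogen, therefore responds to the arm it carries. Nothing available explains the shift. The swap reverses the arm and adds the dimethyl pattern together, so their separate shares cannot be told apart. As far as these compounds go, an amine or a carboxylic acid on that terminal ring also remains open.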